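A few compounds are considered here, and "the series" means these few. Any claim that something is new, unique, unknown or untested is made for them only; others in the source may bear on it.

Measured in an in vivo ADME assay on the whole organism (strain Sprague-Dawley) for pharmacokinetics, with Rattus norvegicus as the target, at a dose of 10 mg/kg by the oral route; a lower number here means that a smaller share of the oral dose reaches the circulation, a higher number that a larger share of the oral dose reaches the circulation:
compound 1 `COc1ncc(C(=O)NC2(C(=O)N[C@H](C)c3ccc(-n4nc(Cl)c5ccccc54)cc3F)CC2)s1` gives 13%;
compound 2 `COc1cncc(C(=O)NC2(C(=O)N[C@H](C)c3ccc(-n4nc(Cl)c5ccccc54)cc3F)CC2)c1` gives 6%.

Compound 2 holds the lower of the two numbers in this assay, yet its gap to compound 1 is within the usual scatter. Within the data shown here, the one measured step, a number 7 percentage points lower from compound 1 to compound 2 (within the scatter), exchanged the whole ring on the carbonyl carbon and stayed within the scatter. Compound 3 `C[C@@H](NC(=O)C1(NC(=O)c2cncc(Br)c2)CC1)c1ccc(-n2nc(Cl)c3ccccc32)cc1F` keeps that ring and alters a single group: bromo in place of methoxy on an aromatic carbon. Among the measured compounds shown here, no measured step touches this group, so the only guide is that the one recorded change left the number essentially unmoved. A small step in this assay is therefore expected, a number 1 percentage points higher from compound 2 to compound 3 (within the scatter). Compound 3 is estimated at 7%, likely between 1% and 20%.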

Compound 3, oral bioavailability: 24%
Beside the measured number, compound 3's estimate is 17 percentage points below it, and the stated range ends below it.
By their numbers in this assay, from the lowest: compounds 2 and 1 (each within the scatter of the next); then compound 3.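

In this assay, the exchange of the whole ring stayed within the scatter, but a change of one group on the pyridine ring goes beyond it: bromo in place of methoxy gives a number 18 percentage points higher from compound 2 to compound 3 (beyond the scatter). The 5-bromopyridin-3-yl group also separates from the 2-methoxy-1,3-thiazol-5-yl group, with a number 11 percentage points higher from compound 1 to compound 3 (beyond the scatter). No measurement shown here accounts for this rise. As far as these compounds go, whether the rise depends on bromo itself or on the loss of methoxy remains open. A chloro, methyl or nitrile group on the same carbon could help separate the two.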